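The source may report more compounds than this note shows. Statements on the series, on what has been measured and on what is new or still open speak of the compounds shown alone.

Measured in a functional assay on HCT-116 cells (Homo sapiens) for cytotoxicity, read by MTT assay, with a stated time of 72 h; a lower number here means a stronger inhibitor, a higher number a weaker inhibitor:
- compound 1 `CN1CCN(CCCn2c3c(c4ccccc42)C(=O)c2c[n+]([O-])c4ccccc4c2C3=O)CC1` gives 560 nM
- compound 2 `O=C1c2c[n+]([O-])c3ccccc3c2C(=O)c2c1c1ccccc1n2CCN1CCCCC1` gives 780 nM

Not yet measured:
- compound 3 `O=C1c2c[n+]([O-])c3ccccc3c2C(=O)c2c1c1ccccc1n2CCCN1CCC(O)CC1`

For the measured compounds named here, with only two numbers, compound 2 at 780 nM has a single neighbour, and the two values lie within the scatter of each other. The step to compound 3 places (4-hydroxypiperidin-1-yl)methyl in place of piperidin-1-yl on a saturated chain carbon, two bonds along the chain from an aromatic nitrogen. Cut one bond further out, this reads 2-(piperidin-1-yl)ethyl to 3-(4-hydroxypiperidin-1-yl)propyl.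

Going by the values given here, one measured step bears on this, as it falls at the same place: a 1.4-fold higher number from compound 1 to compound 2 (0.14 log units; within the scatter). Among the compounds with values here, no measured compound carries the hydroxyl-bearing ring, so this single small step is the only guide, and a wide range is warranted. In this assay the expected step is a 1.2-fold lower number from compound 2 to compound 3 (0.08 log units; within the scatter), which means no change beyond the scatter is expected. For compound 3 the estimated value is 650 nM, with an expected range from 260 nM to 1700 nM.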

Compound 3, half-maximal inhibitory concentration: 190 nM
Compound 3: the middle estimate sits 3.4-fold (0.53 log units) above what was measured; the measured number lies below the stated range.
By their numbers in this assay, from the lowest: compound 3; then compounds 1 and 2 (each within the scatter of the next).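

This position looked flat in the earlier pair, but in this assay it responds with a 4.1-fold lower number from compound 2 to compound 3 (0.61 log units; beyond the scatter) when 2-(piperidin-1-yl)ethyl gives way to 3-(4-hydroxypiperidin-1-yl)propyl, a change that alters the chain and the ring together. The chain stays the same in a 2.9-fold lower number from compound 1 to compound 3 (0.47 log units; beyond the scatter) where 4-hydroxypiperidin-1-yl replaces 4-methylpiperazin-1-yl, so the ring at the end of the chain can by itself move the number beyond the scatter. Nothing at hand accounts for the difference between these rings.

On these data alone, how much of the first step belongs to the hydroxyl and how much to the chain stays open, and 3-(piperidin-1-yl)propyl and 2-(4-hydroxypiperidin-1-yl)ethyl are the two groups that would separate them. Also open, as far as these compounds go, are whether the oxygen must be a free hydroxyl, as against 4-methoxypiperidin-1-yl or a morpholine ring, and whether the 4-hydroxypiperidin-1-yl ring keeps its standing on a longer chain such as a butyl linker.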